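The compounds below may be only part of what the source reports. "The series", "measured", "known", "first", "only" and "open" are said of these compounds alone.

Of the compounds shown here, three of a shared core have been measured in a functional assay on HeLa cells (Homo sapiens) for antiproliferative activity, read by MTT assay, with a stated time of 48 h, in the presence of a further agent that is not named here; a lower number here means a stronger inhibitor of growth, a higher number a weaker inhibitor of growth: compound 1 `O=C(NOCc1ccccc1F)c1cn(-c2ccccc2)nc1-c1ccccc1` gives 11800 nM, compound 2 `COc1ccc(-c2nn(-c3ccccc3)cc2C(=O)NOCc2ccccc2F)cc1` gives 2900 nM, and compound 3 `O=C(NOCc1ccccc1)c1cn(-c2ccccc2)nc1-c1ccc(Cl)cc1` gives 8350 nM. Compound 3 thus stands second highest of the three; its value and that of compound 1 lie within the scatter of each other, while compound 2 sits beyond it. For the measured compounds named here, the only single-point step, a 4.1-fold lower number from compound 1 to compound 2 (0.61 log units; beyond the scatter), concerns a methoxy group on a different ring. Compound 4 `O=C(NOCc1ccccc1F)c1cn(-c2ccccc2)nc1-c1ccc(Cl)cc1` differs from compound 3 by fluoro in place of hydrogen on an aromatic carbon. Going by the values given here, no measured step bears on this change; compound 1 and compound 3 differ in two places, so their values give no clean reading of it. The expected step is therefore a 1.0-fold lower number from compound 3 to compound 4 (0.02 log units; within the scatter), which is none beyond the scatter. Compound 4 is estimated at 8000 nM, with a range from 3500 nM to 19000 nM.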

Compound 4, concentration for 50% growth inhibition: 4170 nM
The estimate for compound 4 lay 1.9-fold (0.28 log units) above the measured number, and the stated range covers the measured number.
By their numbers in this assay, from the lowest: compounds 2, 4, 3 and 1 (each within the scatter of the next, the first and the last beyond it).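

In this assay, fluoro in place of hydrogen with the chloro group present gives a 2.0-fold lower number from compound 3 to compound 4 (0.30 log units; within the scatter) and so shows no change that can be told from scatter at this position. With the 2-fluorobenzyl group held fixed, chloro in place of hydrogen gives a 2.8-fold lower number from compound 1 to compound 4 (0.45 log units; beyond the scatter) and chloro in place of methoxy gives a 1.4-fold higher number from compound 2 to compound 4 (0.16 log units; within the scatter) and so chloro and methoxy cannot be separated here. Nothing available explains these steps. As far as these compounds go, whether an amine or a carboxylic acid in place of the fluoro would move the number stays open.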